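Removing the Trifluoromethyl Group from Compound 2

The source may report more compounds than this note shows. Statements on the series, on what has been measured and on what is new or still open speak of the compounds shown alone.

Compound 1, `COc1ccc2cc(C(C)c3nnc4n3N=C(c3ccc(C)cc3)CS4)ccc2c1`: 11000 nM
Compound 2, `CC(C)Cc1ccc(C(C)c2nnc3n2N=C(c2ccc(C(F)(F)F)cc2)CS3)cc1`: 4200 nM
Compound 3, `COc1ccc2cc(C(C)c3n[nH]c(=S)n3N)ccc2c1`: 22300 nM

Of the compounds shown here, three have been measured in a functional assay on MCF7 cells (Homo sapiens) for inhibition, read by sulforhodamine B assay, with a stated time of 72 h; on this read-out higher numbers stand for weaker inhibition and lower numbers for stronger inhibition. Among them compound 2 stands lowest, and both gaps to the other two lie beyond the usual scatter: compound 1 gives a higher number, and compound 3, which lacks the fused second ring carried by the other two, gives the highest of the three. Among the measured compounds shown here, no pair of measured compounds differs in only one place, so no single change has yet been followed on its own.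

For the measured compounds named here, compound 4, `CC(C)Cc1ccc(C(C)c2nnc3n2N=C(c2ccccc2)CS3)cc1`, is the first such single-change comparison. It differs from compound 2 in one way: hydrogen in place of trifluoromethyl on an aromatic carbon. Going by the values given here, with no comparable step among the measured compounds to lean on, the direction and size of the step can only be guessed from the fact that compound 2 is the best of the three so far. A modest move toward weaker inhibition is expected, one that may or may not clear the scatter; the step of a 1.7-fold higher number from compound 2 to compound 4 (0.22 log units; within the scatter) is the estimate of that move. For compound 4 the expected result in this assay is 7000 nM, within a range from 3000 nM to 18000 nM.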

Compound 4, half-maximal inhibitory concentration: 9700 nM
Estimate against measurement, compound 4: 1.4-fold (0.14 log units) below; the range from low to high includes it.
By their numbers in this assay, from the lowest: compound 2; then compounds 4 and 1 (each within the scatter of the next); then compound 3.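

In this assay, among the compounds shown here, replacing trifluoromethyl with hydrogen gives a 2.3-fold higher number from compound 2 to compound 4 (0.36 log units; beyond the scatter) and is the first single change that can be followed on its own. It shows that this place, on an aromatic carbon para to a large group, is not indifferent to what it carries: 4-(trifluoromethyl)phenyl gives stronger inhibition than phenyl, although the step is modest and rests on this one pair. Nothing measured on the two compounds bears on why the number moves.

The compounds shown leave open whether a chlorine, a nitrile or an amine at this place would match trifluoromethyl, fall back to the level of hydrogen or go beyond either. They also leave open whether the same change would give a similar step on the core of compound 1.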